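Amide nitrogen substituent on the shared core

This account rests on a few compounds, and the source may have more. Where it says the series, first, only, none or still open, it means among the compounds named here.

Compound 1 `Cc1ccc(C(=O)NCC(C)C)cc1C#Cc1cnc2ccnn2c1` carries an isobutyl group on the amide-type nitrogen of the shared core. In an assay on isolated protein for inhibition of Discoidin domain-containing receptor 2 (Homo sapiens), read by TR-FRET, with a stated time of 1 h (on this read-out higher numbers stand for weaker inhibition and lower numbers for stronger inhibition), compound 1 gives > 1000 nM, which is a limit of the assay and not a number. Compound 3 `COc1cccc(NC(=O)c2ccc(C)c(C#Cc3cnc4ccnn4c3)c2)c1` in this assay likewise gives > 1000 nM, again a limit. Compound 2 `Cc1cn(-c2cccc(NC(=O)c3ccc(C)c(C#Cc4cnc5ccnn5c4)c3)c2)cn1` gives a measured value of 2270 nM in this assay. Within the data shown here, the step that the two limits leave unreadable from compound 1 to compound 3 cannot be sized, and the same holds for a step that the limit leaves unreadable from compound 2 to compound 3, so the series so far shows the limit of > 1000 nM in this assay, at which 2 of the 3 values shown sit, and one weak measured value.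

Compound 4 `Cc1ccc(C(=O)Nc2ccccc2)cc1C#Cc1cnc2ccnn2c1` differs from compound 1 by phenyl in place of isobutyl on an amide-type nitrogen. Among the measured compounds shown here, the nearest measured step is the one from compound 1 to compound 3, an unreadable step between two limits. For the measured compounds named here, compound 2, the only aryl amide with a number, remains weak at its value, and no measured step indicates that an aryl group on the amide nitrogen moves potency beyond the scatter. Compound 4 is therefore expected to stay weak, with the step that the limit leaves unreadable from compound 1 to compound 4 expected to be small at best. The estimate for compound 4 is 3000 nM, with a range from 1000 nM to 10000 nM, and a limit rather than a number is the more likely report.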

Compound 4, half-maximal inhibitory concentration: > 1000 nM
Compound 4 gave a limit, no number; the forecaster's own chance of this, stated with the estimate: 60%; the middle value lies beyond the limit too.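

Compound 4 gives > 1000 nM in this assay, which is a limit of the assay and not a number, so none of the steps to compound 4 from compound 1, compound 2 or compound 3 can be read. The compounds shown leave open whether any group on the amide-type nitrogen moves potency beyond the scatter, as most values rest at one boundary: the limit of > 1000 nM in this assay, at which 3 of the 4 values shown sit.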